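One added hydroxy on a compound at the limit

The source may report more compounds than this note shows. Statements on the series, on what has been measured and on what is new or still open speak of the compounds shown alone.

Measured so far, in an ADME assay on PA-1 cells (Homo sapiens) for cytotoxicity, read by MTT assay, with a stated time of 72 h; on this read-out lower numbers stand for stronger inhibition and higher numbers for weaker inhibition
compound 1 `COc1ccc(C2=C(c3cc(OC)c(OC)c(OC)c3)C(=O)CC2O[SiH2]C(C)(C)C)cc1` | > 100 ug/mL
compound 2 `COc1cc(C2=C(c3cc(C)c(OC)c(C)c3)C(OC(C)=O)CC2=O)cc(OC)c1OC` | > 100 ug/mL
compound 3 `COc1ccc(C2=C(c3cc(OC)c(OC)c(OC)c3)C(=O)C(OC(C)=O)C2)cc1F` | > 100 ug/mL

Compound 1 gives > 100 ug/mL in this assay, which is a limit of the assay and not a number. Compound 2 gives > 100 ug/mL, also a limit. Compound 3 gives > 100 ug/mL, again a limit. Compound 1 therefore stands with the other two at the limit of > 100 ug/mL in this assay, at which 3 of the 3 values shown sit, and none of the three offers a number to compare with.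

Compound 4 `COc1ccc(C2=C(c3cc(OC)c(OC)c(OC)c3)C(=O)CC2O[SiH2]C(C)(C)C)cc1O` is compound 1 with a single change: hydroxy in place of hydrogen on an aromatic carbon, which places hydroxy in place of hydrogen on an aromatic carbon, ortho to a methoxy group, and turns 4-methoxyphenyl into 3-hydroxy-4-methoxyphenyl. Among the compounds with values here, no two measured compounds differ in one place only, so no measured step shows what such a change does, and any forecast is a loose judgement.

The expected change is a move towards stronger inhibition, and the estimated step of an at least 5.0-fold lower number from compound 1 to compound 4 (0.69 log units; beyond the scatter) is correspondingly uncertain, since it starts from a limit. A reading at the same limit would be no surprise. For compound 4 the estimated value is 20 ug/mL, with an expected range from 1 ug/mL to 100 ug/mL in this assay.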

Compound 4, half-maximal inhibitory concentration: 14 ug/mL
Beside the measured number, compound 4's estimate is 1.4-fold (0.15 log units) above it; measured number inside the range.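

Compound 1 gives > 100 ug/mL in this assay, which is a limit of the assay and not a number. Placing hydroxy on an aromatic carbon of its six-membered ring, ortho to a methoxy group, turns 4-methoxyphenyl into 3-hydroxy-4-methoxyphenyl and gives an at least 7.1-fold lower number from compound 1 to compound 4 (0.85 log units; beyond the scatter), so this one position can move the shared core from the limit to a value that can be read, and a change of a single heavy atom is enough to do it. Compound 4 is the only one of the four compounds with a real number, which gives later changes a measured point to be compared with, where the others offer none: the limit of > 100 ug/mL in this assay, at which 3 of the 4 values shown sit.

The step is only a minimum, so its true size stays unknown, and the compounds shown do not tell whether the hydroxy itself matters or whether another group at this place, such as an amine or a carboxylic acid, would give a similar reading. They also leave open what happens if the hydroxy is lengthened into an ethoxy chain, or if it is moved elsewhere on the same ring.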